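The source may report more compounds than this note shows. Statements on the series, on what has been measured and on what is new or still open speak of the compounds shown alone.

Measured so far in a functional assay, with a stated time of 19 h; a higher number here means a weaker inhibitor, a lower number a stronger inhibitor:
- compound 1 `COc1ccc(/C=C/C(O)=C/C(=O)/C=C/c2ccc(O)c(CN(C)C)c2)cc1`: 11900 nM
- compound 2 `CN(C)Cc1cc(/C=C/C(=O)/C=C(O)/C=C/c2ccc(F)cc2)ccc1O`: 22300 nM

Only these two compounds have numbers, and they cannot be ranked against each other. Among the compounds with values here, compound 2 therefore stands level with its sole neighbour, and neither can be called the better inhibitor.

The next compound, compound 3 `Cc1ccc(/C=C/C(O)=C/C(=O)/C=C/c2ccc(O)c(CN(C)C)c2)cc1`, keeps the shared core and alters a single group: methyl in place of fluoro on an aromatic carbon. Put simply, methyl in place of fluoro on an aromatic carbon, so that 4-fluorophenyl becomes 4-methylphenyl.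

Within the data shown here, one measured step bears on this change. It swaps a group on the same aromatic carbon, fluoro in place of methoxy, and it gave a 1.9-fold higher number from compound 1 to compound 2 (0.27 log units; within the scatter). Among the measured compounds shown here, that is thin evidence, since no compound with methyl at this place has been measured yet. Even so, that step gives no reason to look for a large shift, and no step beyond the scatter is expected in this assay. The estimated change is a 1.5-fold lower number from compound 2 to compound 3 (0.17 log units; within the scatter).

For compound 3 the expected value is 15000 nM, with an estimated range of 7000 nM to 32000 nM.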

Compound 3, half-maximal inhibitory concentration: 22000 nM
For compound 3 the middle estimate is 1.5-fold (0.17 log units) below the measured one, within the range that was stated.
By their numbers in this assay, from the lowest: compounds 1, 3 and 2 (each within the scatter of the next).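

Putting methyl in place of fluoro on this aromatic carbon, para to a large group, gives a 1.0-fold lower number from compound 2 to compound 3 (0.01 log units; within the scatter) in this assay, so the two cannot be told apart in this assay. Methyl also stands against methoxy at this place, with a 1.8-fold higher number from compound 1 to compound 3 (0.27 log units; within the scatter), which means that three different groups have now been compared here and that no step among them leaves the scatter, where the earlier pair offered only a single step. Nothing available explains why these three groups read alike.

All three groups are small, so the compounds shown leave open whether this place would respond to something quite different, such as an amine, a carboxylic acid or a longer chain like butyl. They also leave open whether changes elsewhere on the shared core, for example to the dimethylaminomethyl group, would move the number beyond the scatter in this assay.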